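Swapping Chloro for Methylpiperazinyl on a Second Core

A few compounds are considered here, and "the series" means these few. Any claim that something is new, unique, unknown or untested is made for them only; others in the source may bear on it.

Measured so far in a physicochemical assay for lipophilicity, using the shake flask method; a lower number here means a more polar compound, a higher number a more lipophilic compound: compound 1 `CC1C(=O)CC(c2ccc(Cl)cc2)N(C(=O)CN2CCN(C)CC2)C1c1ccc(N(C)C)cc1` gives 1.35; compound 2 `COc1ccc(C2C(C)C(=O)CC(c3ccc(F)cc3)N2C(=O)CCl)cc1` gives 1.42; compound 3 `CC1C(=O)CC(c2ccc(Cl)cc2)N(C(=O)CCl)C1c1ccc(N(C)C)cc1` gives 1.24. All three numbers lie within the scatter of one another.

Compound 3 and compound 1 differ in one place, (4-methylpiperazin-1-yl in place of chloro on a saturated chain carbon bound to a carbonyl carbon), and this change made a number 0.11 log units higher from compound 3 to compound 1 (within the scatter). Compound 4 `COc1ccc(C2C(C)C(=O)CC(c3ccc(F)cc3)N2C(=O)CN2CCN(C)CC2)cc1` arises from compound 2 by the same change, (4-methylpiperazin-1-yl in place of chloro on a saturated chain carbon bound to a carbonyl carbon). Compound 2 and compound 3 differ in more than one place; the difference between the two cores is not broken down here. For compound 4 in this assay a step of a number 0.11 log units higher from compound 2 to compound 4 (within the scatter) is expected, resting on a number 0.11 log units higher from compound 3 to compound 1 (within the scatter) seen on the core of compound 3. Compound 4 is therefore estimated at 1.53, with the likely range running from 1.2 to 1.9.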

Compound 4, partition coefficient: 1.53
Compound 4: middle estimate and measured number agree at the digits printed; low and high end bracket the measured number.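

In this assay the change from chloro to 4-methylpiperazin-1-yl gave a number 0.11 log units higher from compound 2 to compound 4 (within the scatter) and, on the other core, a number 0.11 log units higher from compound 3 to compound 1 (within the scatter) in a step of matching size at the digits printed. For the compounds shown here, both steps lie within the scatter, so these two pairs show only that the change gave no step beyond the scatter on either core, and two cores do not establish a rule for the whole series. Nothing measured here gives a reason for this outcome.

The compounds shown leave open whether morpholin-4-yl or dimethylamino in place of chloro at this position would behave in the same way. They also leave open what a longer chain carrying the 4-methylpiperazin-1-yl would give.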